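Swapping a fluorophenyl for a nitrophenyl on a urea

A few compounds are considered here, and "the series" means these few. Any claim that something is new, unique, unknown or untested is made for them only; others in the source may bear on it.

Measured so far:
compound 1, `O=C(Nc1cccc(F)c1)Nc1nc(-c2cc3ccccc3o2)cs1` — 4520 nM
compound 2, `O=C(Nc1ccc([N+](=O)[O-])cc1)Nc1nc(-c2cc3cc(Br)ccc3o2)cs1` — > 200000 nM

In a physicochemical assay, with a stated time of 6 min (a higher number here means a weaker inhibitor, a lower number a stronger inhibitor), compound 1 gives 4520 nM. Within the data shown here, of the two values shown it is the only number; the other is a limit of the assay, not a number, so compound 1 cannot be placed against any other compound. Compound 2, `O=C(Nc1ccc([N+](=O)[O-])cc1)Nc1nc(-c2cc3cc(Br)ccc3o2)cs1`, reaches only > 200000 nM in this assay, which is a limit, and that result is noted as the limit of > 200000 nM in this assay, at which 1 of the 2 values shown sits. Compound 3, `O=C(Nc1nc(-c2cc3ccccc3o2)cs1)Nc1ccccc1[N+](=O)[O-]`, differs from compound 1 in one place: 2-nitrophenyl in place of 3-fluorophenyl on an amide-type nitrogen. No measured step of this kind is shown, so any expectation rests on compound 1 alone. A weakening is expected, with the step from compound 1 to compound 3 estimated at a 4.4-fold higher number from compound 1 to compound 3 (0.65 log units; beyond the scatter). Compound 3 is therefore expected to give about 20000 nM in this assay, within a range from 4000 nM to 150000 nM.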

Compound 3, half-maximal inhibitory concentration: 20300 nM
Compound 3: the middle estimate sits 1.0-fold (0.01 log units) below what was measured, and the stated range covers the measured number.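

In this assay, replacing 3-fluorophenyl with 2-nitrophenyl on the amide-type nitrogen gives a 4.5-fold higher number from compound 1 to compound 3 (0.65 log units; beyond the scatter). Among these compounds, this is the first readable step at this position, and it shows that the group attached there can change the result by more than the usual scatter, with the 2-nitrophenyl compound the weaker inhibitor of the pair. Nothing measured here explains why this swap weakens inhibition.

The step changes both the substituent and its place on the phenyl ring, so the compounds shown cannot separate these two effects. On these data alone, it also remains open how a plain phenyl group, or a phenyl ring carrying an amine or a carboxylic acid, would behave at this position.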